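The compounds below may be only part of what the source reports. "The series", "measured", "known", "first", "only" and "open" are said of these compounds alone.

Measured so far:
compound 1 `C=C(Br)C(=O)Nc1cccc(/C=C2\SC(=O)N(Cc3ccc(F)cc3)C2=O)c1` — in a functional assay on FM3A cells (Mus musculus) for cytotoxicity, read by cell counting, with a stated time of 2 days (on this read-out higher numbers stand for weaker inhibition and lower numbers for stronger inhibition), compound 1 gives 920 nM
compound 2 `Nc1ccc(/C=C2\SC(=O)N(Cc3ccc(F)cc3)C2=O)cc1` — in this assay compound 2 gives 36000 nM

Among the compounds with values here, compound 2 has the highest of the two numbers; its only neighbour, compound 1, sits far lower, a gap beyond the usual scatter, so compound 2 is the weaker inhibitor of the pair. Compound 3 `Nc1cccc(/C=C2\SC(=O)N(Cc3ccc(F)cc3)C2=O)c1` is not yet measured and differs from compound 2 in a single place: 3-aminophenyl in place of 4-aminophenyl on a double-bonded chain carbon bound to a double-bonded ring carbon. Within the data shown here, no measured step of this kind exists to lean on, so only a small move is expected, probably downward, perhaps none beyond the scatter, as a 1.8-fold lower number from compound 2 to compound 3 (0.26 log units; within the scatter). For compound 3 the estimate is 20000 nM, ranging from 6000 nM to 60000 nM.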

Compound 3, half-maximal inhibitory concentration: 140000 nM
For compound 3 the middle estimate is 7.0-fold (0.85 log units) below the measured one, outside the stated range (above it).
By their numbers in this assay, from the lowest: compound 1; then compound 2; then compound 3.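

Shifting the amine matters here: 3-aminophenyl in place of 4-aminophenyl gives a 3.9-fold higher number from compound 2 to compound 3 (0.59 log units; beyond the scatter) and so a weaker inhibitor, which shows that the two placements are not interchangeable. Hydrogen in place of (1-bromoethenyl)carbonyl on the nitrogen gives a 150-fold higher number from compound 1 to compound 3 (2.18 log units; beyond the scatter), a far larger step than the shift of the amine. Nothing measured here explains either step. Still open, from the compounds shown here alone, is whether a plain acetyl group on that nitrogen, without the bromine, would give a number nearer that of compound 1 or that of compound 3.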